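The source may hold more compounds than are shown below. What is called first, only, known or untested is meant among the compounds shown, and "the series" means these compounds.

Series notes, measured in a functional assay on HCT-116 cells (Homo sapiens) for inhibition, read by CCK-8 assay, with a stated time of 72 h, tested at 8 uM; on this read-out lower numbers stand for less inhibition of growth and higher numbers for more inhibition of growth at the one concentration tested:

- compound 1 `CCc1ccc(SCc2ccc(C(=O)Nc3ccccc3N)cc2)cc1`: 79.1%
- compound 2 `Nc1ccccc1NC(=O)/C=C/c1ccc(CSc2cccc3ccccc23)cc1`: 35.2%

Compound 1 stands highest of these two measurements, and compound 2 lies lower by a gap beyond the usual scatter. Within the data shown here, the two compounds differ in more than one place, so their gap isolates no single structural change, and no measured step bears directly on the next comparison.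

Compound 3 `Nc1ccccc1NC(=O)c1ccc(CSc2ccc(F)cc2)cc1` keeps the core of compound 1 and has fluoro in place of ethyl on an aromatic carbon, para to a large group: fluoro in place of ethyl on an aromatic carbon. The same difference reads as 4-ethylphenyl to 4-fluorophenyl. Among the measured compounds shown here, with no measured precedent for this swap, the working expectation in this assay is no step beyond the scatter, with a slight lean downward, as the starting point is compound 1 at 79.1%. The expected change is a number 7.1 percentage points lower from compound 1 to compound 3 (within the scatter). For compound 3 the estimated value is 72%, with an expected range from 52% to 88%.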

Compound 3, percent growth inhibition at one concentration: 90.6%
For compound 3 the middle estimate is 18.6 percentage points below the measured one; measured number outside the range, above it.
By their numbers in this assay, from the lowest: compound 2; then compound 1; then compound 3.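

In this assay, among these compounds, the first single-place comparison of the series falls on an aromatic carbon, para to a large group, where fluoro in place of ethyl gives a number 11.5 percentage points higher from compound 1 to compound 3 (beyond the scatter), a modest step. This position therefore responds to substitution in this read-out, and the ethyl group is not needed to keep growth inhibition high at the one concentration tested: a single fluorine, one heavy atom in place of two carbons, gives the higher number. Nothing available here accounts for the step, so it stands as an observation on this one pair of compounds.

As far as these compounds go, whether the step follows from fluoro entering or from ethyl leaving remains open, as does the outcome with chloro, methoxy, an amine or a carboxylic acid at the same position. The step is also read on the core of compound 1 alone, so its size on another core, such as that of compound 2, and its behaviour at other concentrations stay undetermined.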